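A few compounds are considered here, and "the series" means these few. Any claim that something is new, unique, unknown or untested is made for them only; others in the source may bear on it.

Working notes on the series. Compound 1 `N#C/C(=C\c1ccc[nH]1)C(=O)NCc1ccc(Cl)c(Cl)c1`, compound 2 `N#C/C(=C\c1ccccc1)C(=O)NCc1ccc(Cl)c(Cl)c1` and compound 3 `N#C/C(=C\c1ccc(Cl)cc1)C(=O)NCc1ccc(Cl)c(Cl)c1` share one amide and differ only in the group on the double-bonded chain carbon. In a functional assay on DU-145 cells (Homo sapiens) for inhibition, read by MTT assay, with a stated time of 72 h (on this read-out higher numbers stand for weaker inhibition of growth and lower numbers for stronger inhibition of growth), compound 1 gives > 50000 nM, which is a limit of the assay and not a number. In this assay compound 2 gives 71000 nM, and compound 3 gives 30000 nM. Compound 3 thus holds the lowest of the two numbers; the step of a 2.4-fold lower number from compound 2 to compound 3 (0.37 log units; beyond the scatter) separates it from compound 2, while an at least 1.6-fold lower number from compound 1 to compound 3 (0.22 log units; that floor lies within the scatter) can be read only as a floor.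

Compound 4 `COc1ccc(/C=C(\C#N)C(=O)NCc2ccc(Cl)c(Cl)c2)cc1` is the next step: methoxy in place of chloro on an aromatic carbon. Among the measured compounds shown here, no measured step exchanges one substituent on that ring for another. For the measured compounds named here, the only steps that bear on it are a 2.4-fold lower number from compound 2 to compound 3 (0.37 log units; beyond the scatter), a modest gain from adding chloro in place of hydrogen, and a step that the limit leaves unreadable from compound 1 to compound 2. Whether methoxy keeps that gain cannot be read from these, so the expected step of a 1.3-fold higher number from compound 3 to compound 4 (0.12 log units; within the scatter) is none beyond the scatter, leaning toward a higher number. Compound 4 is estimated at 40000 nM, within 15000 nM to 100000 nM.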

Compound 4, concentration for 50% growth inhibition: 70000 nM
Estimate against measurement, compound 4: 1.8-fold (0.24 log units) below, within the range that was stated.
By their numbers in this assay, from the lowest: compound 3; then compounds 4 and 2 (each within the scatter of the next).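

Among the compounds shown here, the exchange of chloro for methoxy on this aromatic carbon, para to a large group, gives in this assay a 2.3-fold higher number from compound 3 to compound 4 (0.37 log units; beyond the scatter), the first direct comparison of two substituents at this place. Methoxy in place of hydrogen gives a 1.0-fold lower number from compound 2 to compound 4 (0.01 log units; within the scatter), so the modest gain seen with chloro does not carry over to methoxy, and a substituent at this place does not by itself lower the number. Steps from compound 1 cannot be read, because compound 1 carries a limit of the assay and not a number: the limit of > 50000 nM in this assay, at which 1 of the 4 values shown sits.

From the compounds shown here alone, whether an amine or a carboxylic acid at this place would track chloro or methoxy stays open. Also open, going by these compounds, is whether chloro keeps its step when it sits elsewhere on the ring.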